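The source may report more compounds than this note shows. Statements on the series, on what has been measured and on what is new or still open speak of the compounds shown alone.

Three hydroxamic acids carrying a thiosemicarbazone tail have been measured in a functional assay on K562/A02 cells (Homo sapiens) for antiproliferative activity, read by MTT assay; on this read-out lower numbers stand for stronger inhibition and higher numbers for weaker inhibition. Compound 1 `O=C(CCCCCNC(=S)NN=C(c1ccccn1)c1ccccn1)NO` gives 2180 nM, compound 2 `O=C(CCCCCNC(=S)N/N=C(\c1ccccc1)c1ccccn1)NO` gives 2030 nM, and compound 3 `Cc1ccccc1/C(=N/NC(=S)NCCCCCC(=O)NO)c1ccccc1` gives 4220 nM. Compound 3 stands highest of the three; its gap to compound 1 lies within the scatter, while the step of a 2.1-fold higher number from compound 2 to compound 3 (0.32 log units; beyond the scatter) is beyond it, so compound 3 is weaker than compound 2 and not separable from compound 1.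

Compound 4 `O=C(CCCCCNC(=S)N/N=C(\c1ccccc1)c1ccccc1F)NO` has not been measured. It differs from compound 3 only at the substituent of the 2-methylphenyl group: fluoro in place of methyl on an aromatic carbon. For the measured compounds named here, no measured step swaps one small group for another on this ring; the only step in hand, from compound 2 to compound 3, replaces the whole pyridin-2-yl by 2-methylphenyl and is therefore only loosely related. Going by the values given here, with no direct precedent, the step is expected to stay within the scatter, a 1.1-fold lower number from compound 3 to compound 4 (0.02 log units; within the scatter). Compound 4 is estimated at 4000 nM, with a range from 2000 nM to 8000 nM.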

Compound 4, half-maximal inhibitory concentration: 6010 nM
Beside the measured number, compound 4's estimate is 1.5-fold (0.18 log units) below it; low and high end bracket the measured number.
By their numbers in this assay, from the lowest: compounds 2, 1, 3 and 4 (each within the scatter of the next, the first and the last beyond it).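

In this assay, the exchange on the aromatic carbon ortho to a large group gives a 1.4-fold higher number from compound 3 to compound 4 (0.15 log units; within the scatter), so methyl and fluoro cannot be separated at this position. The step of a 3.0-fold higher number from compound 2 to compound 4 (0.47 log units; beyond the scatter) stands alongside a 2.1-fold higher number from compound 2 to compound 3 (0.32 log units; beyond the scatter): both are beyond the scatter, so the rise on replacing pyridin-2-yl is now seen with two different substituted phenyl groups, 2-fluorophenyl and 2-methylphenyl. No supporting data bear on why these numbers differ.

Open, from the compounds shown here alone, is whether an unsubstituted phenyl in place of pyridin-2-yl would give the same rise, which would separate the effect of removing the ring nitrogen from that of adding a substituent. Also open, going by these compounds, is whether a larger group at this position, such as methoxy or an amine, would move the number beyond the scatter.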